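From Pentyl to Cyclohexyl on the Amide Nitrogen

The source may hold more compounds than are shown below. What is called first, only, known or untested is meant among the compounds shown, and "the series" means these compounds.

In a functional assay on QGY7701 cells (Homo sapiens) for cytotoxicity, read by MTT assay, with a stated time of 24 h (on this read-out higher numbers stand for weaker inhibition and lower numbers for stronger inhibition), the three measured compounds read as follows:
Compound 1 `C=CC1=C(C(=O)O)C(c2ccc(F)cc2)OC1` gives > 100000 nM.
Compound 2 `C=CC1=C(C(=O)Nc2ccccc2)C(c2ccc(F)cc2)OC1` gives 46700 nM.
Compound 3 `C=CC1=C(C(=O)NCCCCC)C(c2ccc(F)cc2)OC1` gives > 100000 nM.

Compound 3 stands at a limit of this assay: its value of > 100000 nM is a boundary, not a number. Compound 1 sits at the same kind of limit (the limit of > 100000 nM in this assay, at which 2 of the 3 values shown sit). Only compound 2, the anilide, gives a measured number. The measured steps are an at least 2.1-fold lower number from compound 1 to compound 2 (0.33 log units; beyond the scatter) and an at least 2.1-fold higher number from compound 2 to compound 3 (0.33 log units; beyond the scatter); the step that the two limits leave unreadable from compound 1 to compound 3 cannot be read because both ends are limits.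

Compound 4 `C=CC1=C(C(=O)NC2CCCCC2)C(c2ccc(F)cc2)OC1` differs from compound 3 by cyclohexyl in place of pentyl on an amide-type nitrogen. Going by the values given here, no measured step swaps pentyl for cyclohexyl. The nearest comparison is the step of an at least 2.1-fold higher number from compound 2 to compound 3 (0.33 log units; beyond the scatter), in which a six-membered ring on the amide nitrogen gave way to an open pentyl chain and the number rose at least modestly. Cyclohexyl brings back a six-membered ring, though a non-aromatic one, so compound 4 is expected to lie between compound 3 and compound 2, with a modest drop in number, an at least 1.4-fold lower number from compound 3 to compound 4 (0.15 log units; that floor lies within the scatter), and a real chance that this assay again reports only a limit. The estimate for compound 4 is therefore 70000 nM, between 25000 nM and 200000 nM.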

Compound 4, half-maximal inhibitory concentration: 40500 nM
Estimate against measurement, compound 4: 1.7-fold (0.24 log units) above; the range from low to high includes it.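

On the amide-type nitrogen, cyclohexyl in place of pentyl brings this assay from a limit to a measured number, an at least 2.4-fold lower number from compound 3 to compound 4 (0.39 log units; beyond the scatter), so the open chain and the ring do not read alike at this position. Phenyl and cyclohexyl on this nitrogen cannot be told apart, a 1.2-fold lower number from compound 2 to compound 4 (0.06 log units; within the scatter), which means that among these compounds a measured number does not depend on the ring being aromatic, and the amide with cyclohexylamino also separates from the free acid, an at least 2.4-fold lower number from compound 1 to compound 4 (0.39 log units; beyond the scatter). Both steps that start from compound 3 or compound 1 give only a minimum size, since the value of each of these two compounds is a limit and not a number: the limit of > 100000 nM in this assay, at which 2 of the 4 values shown sit.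

Pentyl and cyclohexyl differ in both ring and carbon count, so it stays open which of the two matters, a question that a hexyl chain and a cyclopentyl ring would help to separate. As far as these compounds go, it is also open whether a benzyl group or a piperidine amide would move the number clearly away from those of compound 2 and compound 4.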